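The compounds below may be only part of what the source reports. "The series", "measured", "known", "first", "only" and "open" are said of these compounds alone.

In the sulforhodamine B test on cancer cells, a functional assay on HT-29 cells (Homo sapiens) for inhibition, read by sulforhodamine B assay, with a stated time of 72 h (a lower number here means a stronger inhibitor, a higher number a weaker inhibitor), compound 1 `COc1cc(/C=C/C(=O)/C=C(/C=C/c2ccc(OC(C)=O)c(OC)c2)NC2CCCCC2)ccc1OC(C)=O` gives > 25000 nM. That value is a limit of the assay and not a measured number.

Two relatives give numbers that can be read directly. Compound 2 `C=CCNC(=C\C(=O)/C=C/c1ccc(O)c(OC)c1)/C=C/c1ccc(O)c(OC)c1` gives 24600 nM, and compound 3 `CC(C)CNC(=C\C(=O)/C=C/c1ccc(O)cc1)/C=C/c1ccc(O)cc1` gives 22500 nM. These two values lie within the usual scatter of each other. For the measured compounds named here, neither compound differs from another measured compound in only one place, so the data show no clean single-change step.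

The next compound to be tested is compound 4 `CCC(C)NC(=C\C(=O)/C=C/c1ccc(OC(C)=O)c(OC)c1)/C=C/c1ccc(OC(C)=O)c(OC)c1`. It keeps the core of compound 1 and carries sec-butyl in place of cyclohexyl on an amine nitrogen.

Going by the values given here, with no measured step to guide it, the expectation is for no change beyond the scatter in this assay, and no firm direction can be given. The nearest guides are compound 2 at 24600 nM and compound 3 at 22500 nM, which also carry open-chain groups on the amine nitrogen. The estimated step is an at least 1.2-fold lower number from compound 1 to compound 4 (0.09 log units; that floor lies within the scatter), which is expected to stay within the usual scatter. Compound 4 is estimated at 20000 nM, with an expected range of 8000 nM to 35000 nM.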

Compound 4, half-maximal inhibitory concentration: > 25000 nM
Compound 4: a limit, no number (the forecaster's own chance of this, stated with the estimate: 35%); middle value at least 1.2-fold (0.09 log units) away from the limit.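

In this assay compound 4 gives > 25000 nM, which is a limit of the assay and not a number. Compound 1 also stands at a limit, so no step can be read between compound 1 and compound 4: the limit of > 25000 nM in this assay, at which 2 of the 4 values shown sit.

The compounds shown leave open whether sec-butyl in place of cyclohexyl on an amine nitrogen changes the result at all.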